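The compounds below may be only part of what the source reports. "The series", "measured", "known", "first", "only" and "open" are said of these compounds alone.

Three compounds have been measured in a toxicity assay (Homo sapiens) for cytotoxicity, read by MTT assay, with a stated time of 48 h; a lower number here means a stronger inhibitor, a higher number a weaker inhibitor:

compound 1 `O=C1C(O)=C(C(c2cccc([N+](=O)[O-])c2)c2c[nH]c3ccccc23)C(=O)c2ccccc21`, giving 91200 nM;
compound 2 `Cc1[nH]c2ccccc2c1C(C1=C(O)C(=O)c2ccccc2C1=O)c1ccc(Cl)cc1`, giving 40300 nM;
compound 3 `O=C1C(O)=C(C(c2ccc([N+](=O)[O-])cc2)c2c(-c3ccccc3)[nH]c3ccccc23)C(=O)c2ccccc21`, giving 14200 nM.

Compound 1 stands at the highest of the three numbers. Compound 2 is nearest to it, with a lower number by a margin beyond the scatter, and compound 3 is furthest, lower still and also beyond the scatter. Among the compounds with values here, no two of these measured compounds differ from each other in a single place, so no step between measured compounds can be drawn from them.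

Compound 4 `COc1cccc(C(C2=C(O)C(=O)c3ccccc3C2=O)c2c[nH]c3ccccc23)c1` has not yet been measured in this assay. It differs from compound 1 in one place: methoxy in place of nitro on an aromatic carbon. Within the data shown here, nothing among the measured compounds speaks directly to this exchange, since compound 2 and compound 3 each differ from compound 1 at more than one place and neither carries a methoxy group. The expectation for compound 4 therefore rests on compound 1 alone, whose 91200 nM is the starting point. The step of a 1.2-fold lower number from compound 1 to compound 4 (0.08 log units; within the scatter) is expected to remain within the scatter, with no direction claimed beyond it. Compound 4 is accordingly estimated at 75000 nM in this assay, with a range from 25000 nM to 220000 nM.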

Compound 4, half-maximal inhibitory concentration: 110000 nM
Estimate against measurement, compound 4: 1.5-fold (0.17 log units) below; measured number inside the range.
By their numbers in this assay, from the lowest: compound 3; then compound 2; then compounds 1 and 4 (each within the scatter of the next).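

In this assay, putting methoxy in place of nitro, on the aromatic carbon meta to a large group, gives a 1.2-fold higher number from compound 1 to compound 4 (0.08 log units; within the scatter), and this step lies within the scatter, so compound 1 and compound 4 cannot be told apart. Within the data shown here, this is the first comparison that isolates a single place, and it shows that 3-nitrophenyl and 3-methoxyphenyl read alike here on the core of compound 1, even though the two groups differ in their atoms and in their counts of hydrogen-bond acceptors. No measurement at hand explains this likeness.

Going by these compounds, whether any group at this place can move the number beyond the scatter remains open, since a single exchange says nothing about an amine, a carboxylic acid or a longer chain such as propoxy there. Also open, on these data alone, is whether the exchange of nitro for methoxy would read the same in a compound that also carries a methyl or phenyl group on the shared core, as compound 2 and compound 3 do, since each of those two differs from compound 1 at more than one place.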